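Swapping a Hydroxy for a tert-Butyl in a Hydrazone Series

The source may hold more compounds than are shown below. What is called first, only, known or untested is meant among the compounds shown, and "the series" means these compounds.

Measured so far in a physicochemical assay, read by spectrophotometry, with a stated time of 60 min, tested at 300 uM; a higher number here means a stronger effect of the compound at the concentration tested, a lower number a weaker effect:
compound 1, `COc1cc(/C=C/C=N/NC(=O)c2ccc(C(C)(C)C)cc2)ccc1O`: compound 1 gives 75.1%
compound 2, `O=C(N/N=C/c1ccc(O)cc1)c1ccc(O)cc1`: compound 2 gives 54.4%

Of the compounds shown here, two share a hydrazone-amide core and have been tested in this assay. Compound 2 stands lowest of the two numbers; its nearest neighbour is compound 1, whose read-out lies higher by a margin beyond the usual scatter. Going by the values given here, compound 1 and compound 2 differ in more than one place, so their two values show only that the pair sits apart, not what any single group contributes.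

Compound 3, `CC(C)(C)c1ccc(C(=O)N/N=C/c2ccc(O)cc2)cc1`, has not yet been measured. It differs from compound 2 in one place: tert-butyl in place of hydroxy on an aromatic carbon. Among the compounds with values here, compound 1 also carries a tert-butyl on its benzoyl ring, but its other half is different, so no clean step for this change exists among the measured pair. The step from compound 2 to compound 3 in this assay is therefore expected to be modest and upward, possibly no larger than the scatter, giving a number 7.6 percentage points higher from compound 2 to compound 3 (within the scatter). On that basis compound 3 is estimated at 62%, with a range from 48% to 76%.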

Compound 3, a percentage reported as inhibition, at one concentration (the size of the read-out at that concentration, not a potency): 28.9%
For compound 3 the middle estimate is 33.1 percentage points above the measured one; measured number outside the range, below it.
By their numbers in this assay, from the lowest: compound 3; then compound 2; then compound 1.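

Going by these compounds alone, replacing hydroxy with tert-butyl on this aromatic carbon, para to a large group, gives a number 25.5 percentage points lower from compound 2 to compound 3 (beyond the scatter) in this assay and is the first change here that can be read at a single place. The rest of compound 2 stays the same in compound 3, so the lower read-out goes with this one swap and shows that the group at this position matters in this test at the concentration used. The swap is also not a neutral exchange of one substituent for another, since a small group with a hydrogen-bond donor and acceptor leaves and a larger all-carbon group with neither enters.

Going by these compounds, a single step cannot separate those differences, so it remains open whether the loss of the hydroxy, the arrival of the tert-butyl, or both go with the drop, and an amine, a methoxy group or a methyl group at this carbon would help to tell these apart. Nothing available offers a measured explanation for the size or direction of this step.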